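Lipophilicity notes: fluoro for 1-hydroxyethyl on the benzyl ring

The source may report more compounds than this note shows. Statements on the series, on what has been measured and on what is new or still open speak of the compounds shown alone.

Measured compounds:
- compound 1, `CNC(=O)c1cccn(Cc2ccccc2)c1=O`: 3
- compound 2, `CNC(=O)c1cc(C(=O)NC2CC2)cn(Cc2cccc([C@@H](C)O)c2)c1=O`: 2.2
- compound 3, `CNC(=O)c1cc(C(=O)NC(C)C)cn(Cc2ccccc2)c1=O`: 3.6

In a physicochemical assay for lipophilicity, at pH 7.4 (on this read-out higher numbers stand for higher lipophilicity and lower numbers for lower lipophilicity), compound 2 gives the lowest of the three numbers. Its nearest neighbour is compound 1; compound 3 is furthest away, and both gaps lie beyond the scatter. Going by the values given here, the one step that can be traced within the measured set, a number 0.60 log units higher from compound 1 to compound 3 (beyond the scatter), concerns a different position and tells nothing directly about the change now in question.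

Compound 4, `CNC(=O)c1cc(C(=O)NC2CC2)cn(Cc2cccc(F)c2)c1=O`, differs from compound 2 in a single place: fluoro in place of 1-hydroxyethyl on an aromatic carbon. The group that leaves carries the only hydrogen-bond donor and acceptor outside the shared core in compound 2; the group that enters carries none. Among the compounds with values here, no measured pair in this assay shares this change, so the expectation rests on the values of compound 2 and compound 3 alone: compound 3, with a benzyl ring bearing no substituent, sits well above compound 2, and compound 4 is expected to move back toward that level. The step of a number 1.20 log units higher from compound 2 to compound 4 (beyond the scatter) is therefore expected to be an increase beyond the scatter. For compound 4 the estimate is 3.4, within 3 to 3.8.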

Compound 4, distribution coefficient: 3.2
Beside the measured number, compound 4's estimate is 0.20 log units above it; the measured number falls inside the stated range.
By their numbers in this assay, from the lowest: compound 2; then compounds 1 and 4 (each within the scatter of the next); then compound 3.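

In this assay, the aromatic carbon meta to a large group on the benzyl ring proves sensitive to substitution: fluoro in place of 1-hydroxyethyl gives a number 1.00 log units higher from compound 2 to compound 4 (beyond the scatter) in a modest step. Going by these compounds alone, this is the first reading at this position, as the only earlier step, a number 0.60 log units higher from compound 1 to compound 3 (beyond the scatter) for the isopropylcarbamoyl change, lies at a different place. The step is also a bundled one, with 3 heavy atoms, 1 hydrogen-bond donor, 1 hydrogen-bond acceptor and 1 defined stereocentre leaving together and a single fluorine entering, and no measurement available here bears on the reason for the shift.

Within the data shown here, the single pair cannot separate the contributions of the hydroxyl oxygen and the carbon chain, or show whether fluoro itself matters more than the loss of 1-hydroxyethyl. Still open, on these data alone, are the readings for a methoxy group, an amine or a carboxylic acid at this same aromatic carbon, and whether a step of this size holds when the cyclopropyl amide is replaced by another amide.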